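The source may hold more compounds than are shown below. What is called first, only, known or untested is meant among the compounds shown, and "the series" means these compounds.

Measured so far:
Compound 1, `c1ccc(CCC[C@H]2C3CCC(C3)[C@H]2NC2=NCCO2)cc1`: in an assay on cells for inhibition of Alpha-2C adrenergic receptor (Homo sapiens) (on this read-out higher numbers stand for weaker inhibition and lower numbers for stronger inhibition), compound 1 gives 123 nM.
Compound 2, `CCC[C@H]1C2CCC(C2)[C@H]1NC1=NCCO1`: in this assay compound 2 gives 123 nM.

Compound 2 stands level with compound 1 on these numbers. Going by the values given here, the one measured step, no change at the digits printed from compound 1 to compound 2 (within the scatter), removed a phenyl on a saturated chain carbon three bonds along the chain from a saturated ring carbon and left the inhibition constant unchanged within the scatter.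

Compound 3, `c1ccc(C[C@H]2C3CCC(C3)[C@H]2NC2=NCCO2)cc1`, differs from compound 2 by phenyl in place of ethyl on a saturated chain carbon bound to a saturated ring carbon. This change is not the same as the measured one: it shortens the chain and places the phenyl at a different point, bound directly to the ring carbon rather than farther out. The measured step from compound 1 to compound 2 bears on it only loosely, showing that a phenyl at the far end of the chain made no difference. On that basis a small step in this assay is expected, with no firm direction, and the step from compound 2 to compound 3 is estimated as a 1.2-fold higher number from compound 2 to compound 3 (0.09 log units; within the scatter). Compound 3 is therefore expected to give about 150 nM, in a range from 40 nM to 600 nM.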

Compound 3, inhibition constant: 79.4 nM
Beside the measured number, compound 3's estimate is 1.9-fold (0.28 log units) above it, within the range that was stated.
By their numbers in this assay, from the lowest: compounds 3, 1 and 2 (each within the scatter of the next).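

In this assay the change of ethyl to phenyl on a saturated chain carbon bound to a saturated ring carbon gives a 1.5-fold lower number from compound 2 to compound 3 (0.19 log units; within the scatter) and so does not separate the two groups at this place, although the entering group brings one six-membered aromatic ring of carbon only where the leaving group has no ring. The earlier step, no change at the digits printed from compound 1 to compound 2 (within the scatter), concerned only a phenyl on a saturated chain carbon three bonds along the chain from a saturated ring carbon, so it could not speak for a phenyl on the chain carbon bound to the ring carbon. Nothing here gives a measured reason why these numbers stay within the scatter of each other.

Both steps shown lie within the scatter, so the compounds do not show what kind of group at this place would shift the inhibition constant by more than that. As far as these compounds go, an amine, a carboxylic acid or a hydroxyl on this chain carbon remains open, as does a phenyl carrying a chlorine or a methoxy group, and each would need its own value in this assay before anything could be said of it.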